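Swapping Butyl for Cyclohexyl: What to Expect

A few compounds are considered here, and "the series" means these few. Any claim that something is new, unique, unknown or untested is made for them only; others in the source may bear on it.

Compound 1, `O=C(/C=C/c1ccc([N+](=O)[O-])o1)c1ccc(Br)cc1`, in an ADME assay on cells (Astrocyte, Rattus norvegicus, strain Wistar) for inhibition, read by sulforhodamine B assay, with a stated time of 72 h; on this read-out higher numbers stand for lower toxicity in this test and lower numbers for higher toxicity in this test: 85400 nM
Compound 2, `CCCCc1ccc(C(=O)/C=C/c2ccc([N+](=O)[O-])o2)cc1`, in this assay: 41200 nM

Compound 2 holds the lowest of the two numbers, with compound 1 the nearest. Among the measured compounds shown here, the one measured step, a 2.1-fold lower number from compound 1 to compound 2 (0.32 log units; beyond the scatter), is modest. Compound 3, `O=C(/C=C/c1ccc([N+](=O)[O-])o1)c1ccc(C2CCCCC2)cc1`, differs from compound 2 by cyclohexyl in place of butyl on an aromatic carbon. For the measured compounds named here, no measured step covers this exchange, so the bromo-to-butyl step gives only a loose hint of direction. A small shift toward lower numbers is expected, a 1.4-fold lower number from compound 2 to compound 3 (0.14 log units; within the scatter), possibly within the scatter. Compound 3 is therefore estimated at 30000 nM, between 12000 nM and 80000 nM.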

Compound 3, half-maximal cytotoxic concentration: 57200 nM
The estimate for compound 3 lay 1.9-fold (0.28 log units) below the measured number; the range from low to high includes it.
By their numbers in this assay, from the lowest: compounds 2, 3 and 1 (each within the scatter of the next, the first and the last beyond it).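

Replacing the open butyl chain with the cyclohexyl ring at this position makes no clear difference in this assay (a 1.4-fold higher number from compound 2 to compound 3 (0.14 log units; within the scatter)). Cyclohexyl in place of bromo also stays within the scatter (a 1.5-fold lower number from compound 1 to compound 3 (0.17 log units; within the scatter)), whereas butyl in place of bromo lay just beyond it, so compound 1 and compound 2 mark the only readable gap among these three. No measurement here offers a cause for these numbers. Still open, going by these compounds, is whether an amine or a carboxylic acid at this position would shift the number further, and whether a longer chain would.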